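The compounds below may be only part of what the source reports. "The series", "measured", "known", "first", "only" and "open" are said of these compounds alone.

Measured so far:
compound 1 `O=C(NO)c1ccc(CN(CCCCO)C(=O)Nc2ccccc2)cc1` — 0.87 nM
compound 2 `CCCCN(Cc1ccc(NC(=O)CN)cc1)C(=O)Nc1ccccc1` — "not active" (no number reported)

In an assay on Sf9 cells for inhibition of protein deacetylase HDAC6 (Homo sapiens), read by fluorescence, with stated times of 10 min and 2 h (on this read-out lower numbers stand for stronger inhibition and higher numbers for weaker inhibition), compound 1 gives 0.87 nM. Compound 2 differs from compound 1 in more than one place. In this assay compound 2 is reported as "not active" (no number reported). No single number stands for compound 2, so its place on the scale is known only as well away from compound 1. For the measured compounds named here, no step between measured compounds is available to lean on. Compound 3 `CCCCN(Cc1ccc(/C(N)=N/O)cc1)C(=O)Nc1ccccc1` is still to be measured in this assay. The change from compound 2 to compound 3 is a group of 4 heavy atoms (1 carbon, 2 nitrogen, 1 oxygen; no ring) in place of a group of 5 heavy atoms (2 carbon, 2 nitrogen, 1 oxygen; no ring), on an aromatic carbon. Compound 2 carries no number, so the size of the step cannot be taken from data; the expectation is that compound 3 shows measurable inhibition in this assay while remaining far from compound 1. Compound 3 is expected to give about 5000 nM, within 500 nM to 50000 nM, and a limit rather than a number stays a real possibility.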

Compound 3, half-maximal inhibitory concentration: "not active" (no number reported)
Compound 3 has no reported number here; the estimate stays without a comparison.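

No step can be read from compound 2 to compound 3, since both are reported as "not active" in this assay and neither carries a number. No measured evidence bears on this result. The compounds shown leave open which structural change separates these two from compound 1.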